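The source may report more compounds than this note shows. Statements on the series, on what has been measured and on what is new or still open speak of the compounds shown alone.

Working notes on the series.

Compound 1 `CC(=O)c1ccc(N2CCN(C(=O)c3oc(C)nc3-c3ccccc3)CC2)cc1` is the starting point. In a functional assay on HL-60 cells (Homo sapiens) for inhibition, read by MTT assay, with a stated time of 72 h (on this read-out lower numbers stand for stronger inhibition and higher numbers for weaker inhibition), compound 1 gives "not active" (no number reported), so no single number stands for it and its place on the scale is open; it can only be read as weaker than the measured members. Among the measured compounds shown here, the two measured members differ from compound 1 in more than one place. Compound 2 `COc1cc(OC)cc(N2CCN(C(=O)c3sc(C)nc3-c3ccccc3F)CC2)c1` gives 96.8 nM in this assay. Compound 3 `COc1cc(-c2nc(C)oc2C(=O)N2CCN(c3cccc(Cl)c3)CC2)ccc1OP(=O)(O)O` gives 303 nM in this assay; its values and those of compound 2 show that this core family can reach the sub-micromolar range.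

Compound 4 `Cc1nc(-c2ccccc2)c(C(=O)N2CCN(c3cccc(C#N)c3)CC2)o1` is not yet measured. It differs from compound 1 by one change: 3-cyanophenyl in place of 4-acetylphenyl on an amine nitrogen in a ring. For the measured compounds named here, no measured pair shows this change on its own, so the size of the step in this assay is not known; the expectation is for a step toward stronger inhibition, but with a real chance that compound 4, like compound 1, returns no number. Compound 4 is estimated at 600 nM in this assay, with a range from 100 nM to 5000 nM.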

Compound 4, half-maximal inhibitory concentration: 39.6 nM
Estimate against measurement, compound 4: 15-fold (1.18 log units) above; the measured number lies below the stated range.
By their numbers in this assay, from the lowest: compound 4; then compound 2; then compound 3.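

No step can be read for compound 4: in this assay compound 1 gives "not active" (no number reported), and compound 2 and compound 3 differ from compound 4 in more than one place. Nothing measured here accounts for the result. The compounds shown leave open what 3-cyanophenyl contributes on its own.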